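The source may hold more compounds than are shown below. What is called first, only, known or untested is meant among the compounds shown, and "the series" means these compounds.

Working notes on the series, three compounds measured and one still open.

Compound 1 `O=C(/C=C/c1ccc(Oc2ncnc3ccc(Cl)cc23)cc1)/C=C/c1c(Cl)cccc1Cl` gives 9300 nM in a functional assay on PC-3 cells (Homo sapiens) for inhibition, read by MTT assay, with a stated time of 72 h; on this read-out higher numbers stand for weaker inhibition and lower numbers for stronger inhibition. Compound 2 `O=C(/C=C/c1ccc(Cl)c([N+](=O)[O-])c1)/C=C/c1ccccc1Oc1ncnc2ccc(Cl)cc12` gives 9760 nM in this assay, and compound 3 `O=C(/C=C/c1ccc(Oc2ncnc3ccc(Cl)cc23)cc1)/C=C/c1cccc(Cl)c1Cl` gives 10200 nM. Compound 2 thus sits among three numbers that all lie within the scatter of one another, so no order among them can be read.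

Compound 4 `O=C(/C=C/c1ccccc1Oc1ncnc2ccc(Cl)cc12)/C=C/c1c(Cl)cccc1Cl` is not yet measured. Its difference from compound 2 is 2,6-dichlorophenyl in place of 4-chloro-3-nitrophenyl on a double-bonded chain carbon bound to a double-bonded chain carbon. Among the compounds with values here, the only measured step that touches this part of the molecule is a 1.1-fold higher number from compound 1 to compound 3 (0.04 log units; within the scatter), which swapped one dichlorophenyl pattern for another and changed nothing beyond the scatter. Within the data shown here, no measured step exchanges the 4-chloro-3-nitrophenyl for a dichlorophenyl, so that part of the change has no precedent here; what can be said is that compound 1, which also carries the 2,6-dichlorophenyl, gives 9300 nM, close to the value of compound 2.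

On this basis the step expected in this assay is a 1.0-fold lower number from compound 2 to compound 4 (0.01 log units; within the scatter), that is none beyond the scatter. Compound 4 is therefore estimated at 9600 nM, with a range from 4500 nM to 20000 nM.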

Compound 4, half-maximal inhibitory concentration: 7980 nM
The estimate for compound 4 lay 1.2-fold (0.08 log units) above the measured number, within the range that was stated.
By their numbers in this assay, from the lowest: compounds 4, 1, 2 and 3 (each within the scatter of the next).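

At the double-bonded chain carbon bound to a double-bonded chain carbon, this assay now gives a measured step for exchanging 4-chloro-3-nitrophenyl for 2,6-dichlorophenyl, a 1.2-fold lower number from compound 2 to compound 4 (0.09 log units; within the scatter), on the core of compound 2. Earlier, this position had shown only one dichlorophenyl pattern replacing another, on the core of compound 1; it now shows that a change of the substituents on the phenyl ring, with the nitro group gone, also stays within the scatter. Nothing at hand accounts for this flat result.

Open, as far as these compounds go, is whether a group other than a substituted phenyl at this place, such as an amine, a carboxylic acid or a longer chain, would give a step beyond the scatter. Also open, from the compounds shown here alone, is whether 2,3-dichlorophenyl and 2,6-dichlorophenyl stay within the scatter of each other on the core of compound 4.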